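Sulfonamide in place of amide on the propyl-linked aniline

The source may hold more compounds than are shown below. What is called first, only, known or untested is meant among the compounds shown, and "the series" means these compounds.

The three measured compounds share a core and differ only in the group carried on the amine nitrogen of the side chain. In a functional assay on SK-MEL-28 cells (Homo sapiens) for cytotoxicity, read by MTT assay (on this read-out lower numbers stand for stronger inhibition and higher numbers for weaker inhibition), compound 1 `O=S(=O)(NCCCNc1nccc(-c2c(-c3cccc(F)c3)nc3sccn23)n1)c1cccc(F)c1` gives 8550 nM. Compound 2 `O=S(=O)(NCCNc1nccc(-c2c(-c3cccc(F)c3)nc3sccn23)n1)c1ccc(Br)cc1`, with a shorter chain and a different aryl sulfonyl, gives 13500 nM in this assay, and the step of a 1.6-fold higher number from compound 1 to compound 2 (0.20 log units; within the scatter). Compound 3 `O=C(NCCCNc1nccc(-c2c(-c3cccc(F)c3)nc3sccn23)n1)c1ccc(Cl)cc1` carries an aryl carbonyl instead of an aryl sulfonyl; in this assay compound 3 reaches only the limit of > 20000 nM, and this is a limit, not a number. Compound 3 therefore stands at the weak end of what is shown, at the limit of > 20000 nM in this assay, at which 1 of the 3 values shown sits.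

Compound 4 `Cc1ccc(S(=O)(=O)NCCCNc2nccc(-c3c(-c4cccc(F)c4)nc4sccn34)n2)cc1` differs from compound 3 by (4-methylphenyl)sulfonyl in place of (4-chlorophenyl)carbonyl on an amine nitrogen. The step that bears on this is an at least 2.3-fold higher number from compound 1 to compound 3 (0.36 log units; beyond the scatter), which runs in the opposite direction, and likewise an at least 1.4-fold higher number from compound 2 to compound 3 (0.17 log units; that floor lies within the scatter). Restoring the sulfonyl is therefore expected to bring compound 4 back into the range of compounds 1 and 2, a step of an at least 2.0-fold lower number from compound 3 to compound 4 (0.30 log units; that floor lies within the scatter) toward a lower number. Compound 4 is estimated at 10000 nM in this assay, with a range from 4000 nM to 25000 nM.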

Compound 4, half-maximal inhibitory concentration: 9500 nM
Estimate against measurement, compound 4: 1.1-fold (0.02 log units) above; the range from low to high includes it.
By their numbers in this assay, from the lowest: compounds 1, 4 and 2 (each within the scatter of the next). At a limit, above all of these: compound 3.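

With the propyl-linked chain held, (4-methylphenyl)sulfonyl in place of (4-chlorophenyl)carbonyl on the amine nitrogen gives in this assay an at least 2.1-fold lower number from compound 3 to compound 4 (0.32 log units; beyond the scatter), a comparison in which both groups carry a 4-substituted phenyl, unlike the earlier step from compound 1 to compound 3. The sulfonyl compounds also stay together, with a 1.1-fold higher number from compound 1 to compound 4 (0.05 log units; within the scatter) for 4-methylphenyl in place of 3-fluorophenyl on a sulfonyl sulfur and a 1.4-fold lower number from compound 2 to compound 4 (0.15 log units; within the scatter), so neither change separates them in this read-out. Compound 3, the only aryl carbonyl shown, stands at a limit and not at a number: the limit of > 20000 nM in this assay, at which 1 of the 4 values shown sits.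

From the compounds shown here alone, what stays open is how much of the step belongs to the sulfonyl and how much to methyl in place of chlorine on the phenyl ring, a question that a 4-chlorophenyl sulfonyl or a 4-methylphenyl carbonyl on the same chain would settle. Also open, going by these compounds, is how this assay would respond to a longer chain or to an amine on the phenyl ring of the sulfonyl.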